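Permeability across a diaryl ether to biaryl switch in the series

The compounds below may be only part of what the source reports. "The series", "measured", "known", "first", "only" and "open" are said of these compounds alone.

Measured so far in an ADME assay for permeability, using PAMPA, with a stated time of 30 min, at pH 7.4; a higher number here means that the compound crosses the layer faster, a lower number that the compound crosses the layer more slowly:
compound 1 `COc1ccccc1Oc1ccc2c(NCCCNCc3ccco3)ccnc2c1` gives 317 10^-6 cm/s
compound 2 `CC(C)Cc1ccc2c(NCCCNCc3ccco3)ccnc2c1` gives 23 10^-6 cm/s
compound 3 `c1ccc(Oc2ccc3c(NCCCNCc4ccco4)ccnc3c2)cc1` gives 317 10^-6 cm/s

Compound 3 stands level with compound 1 at the digits given, the two together the highest of the three; the step of a 14-fold higher number from compound 2 to compound 3 (1.14 log units; beyond the scatter) is large, while no change at the digits printed from compound 1 to compound 3 (within the scatter) is within the scatter. Compound 4 `c1ccc(-c2ccc3c(NCCCNCc4ccco4)ccnc3c2)cc1` differs from compound 3 by phenyl in place of phenoxy on an aromatic carbon. Among the compounds with values here, none of the measured steps covers this exact change: a 14-fold lower number from compound 1 to compound 2 (1.14 log units; beyond the scatter) and a 14-fold higher number from compound 2 to compound 3 (1.14 log units; beyond the scatter) concern an aromatic ring against a branched chain, and no change at the digits printed from compound 1 to compound 3 (within the scatter) a methoxy against hydrogen. An aromatic ring remains in place here, so a step within the scatter is expected, a 1.2-fold lower number from compound 3 to compound 4 (0.09 log units; within the scatter). For compound 4 the estimate in this assay is 260 10^-6 cm/s, range 120 10^-6 cm/s to 480 10^-6 cm/s.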

Compound 4, apparent permeability: 237 10^-6 cm/s
Compound 4: the middle estimate sits 1.1-fold (0.04 log units) above what was measured; the measured number falls inside the stated range.
By their numbers in this assay, from the lowest: compound 2; then compounds 4, 1 and 3 (each within the scatter of the next).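

In this assay, a directly attached phenyl is not told apart from the ether-linked rings at this position (a 1.3-fold lower number from compound 3 to compound 4 (0.13 log units; within the scatter); a 1.3-fold lower number from compound 1 to compound 4 (0.13 log units; within the scatter)). The ether oxygen is therefore not needed for the gap to isobutyl, which remains large without it (a 10-fold higher number from compound 2 to compound 4 (1.01 log units; beyond the scatter)). Nothing available accounts for these numbers.

Open, as far as these compounds go, is whether a cyclohexyl ring in the same place would stay with the aromatic groups or fall towards isobutyl. Also open, from the compounds shown here alone, is what a carboxylic acid or an amine on the phenyl ring of compound 4 would do to the read-out.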